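The source may hold more compounds than are shown below. What is called first, only, known or untested is meant among the compounds shown, and "the series" means these compounds.

The series starts from compound 1 `O=C1CCCC/C1=C\c1ccc(OC(=O)c2ccc(Cl)cc2)cc1`, which in a functional assay on CCRF-CEM cells (Homo sapiens) (on this read-out lower numbers stand for stronger inhibition and higher numbers for weaker inhibition), gives compound 1 a value of 41000 nM. Compound 2 `COc1ccc(C(=O)Oc2ccc(/C=C3\CCCCC3=O)cc2)cc1` differs from compound 1 by methoxy in place of chloro on an aromatic carbon, and in this assay compound 2 gives 36100 nM; the step is a 1.1-fold lower number from compound 1 to compound 2 (0.06 log units; within the scatter). Compound 3 `CN(C)CC1CCC/C(=C\c2ccc(OC(=O)c3ccc(Cl)cc3)cc2)C1=O` keeps the chloro group but has a different core: compound 3 differs from compound 1 by (dimethylamino)methyl in place of hydrogen on a saturated ring carbon. In this assay compound 3 gives 6150 nM, and the step is a 6.7-fold lower number from compound 1 to compound 3 (0.82 log units; beyond the scatter). Compound 3 is the lowest number of the three, with its steps to compound 1 and compound 2 both beyond the scatter.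

Compound 4 `COc1ccc(C(=O)Oc2ccc(/C=C3\CCCC(CN(C)C)C3=O)cc2)cc1` is not yet measured. Compound 4 differs from compound 3 by methoxy in place of chloro on an aromatic carbon, and the place of this change is the same as in the pair of compound 1 and compound 2, so it is the same change, here made on the core of compound 3 rather than on the core of compound 1. That change occurs twice among the four compounds, once measured and once not.

For the measured compounds named here, the expectation rests on the one measured instance: in this assay the expected step is a 1.1-fold lower number from compound 3 to compound 4 (0.04 log units; within the scatter) because a 1.1-fold lower number from compound 1 to compound 2 (0.06 log units; within the scatter). Compound 4 is therefore estimated at 5600 nM, with a likely range from 2800 nM to 11000 nM.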

Compound 4, half-maximal inhibitory concentration: 5070 nM
Estimate against measurement, compound 4: 1.1-fold (0.04 log units) above; low and high end bracket the measured number.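

In this assay, methoxy in place of chloro on the core of compound 3 gives a 1.2-fold lower number from compound 3 to compound 4 (0.08 log units; within the scatter) and this step agrees with the one measured on the core of compound 1: the same change on two cores in this assay, a 1.1-fold lower number (0.06 log units; within the scatter) from compound 1 to compound 2 and a 1.2-fold lower number (0.08 log units; within the scatter) from compound 3 to compound 4, 1.1-fold (0.03 log units) apart, within the scatter of two such steps. The other change in these four compounds also carries over, since (dimethylamino)methyl in place of hydrogen on a saturated ring carbon, now with methoxy rather than chloro on the aromatic ring, gives a 7.1-fold lower number from compound 2 to compound 4 (0.85 log units; beyond the scatter) and this step matches its chloro counterpart: the same change on two cores in this assay, a 6.7-fold lower number (0.82 log units; beyond the scatter) from compound 1 to compound 3 and a 7.1-fold lower number (0.85 log units; beyond the scatter) from compound 2 to compound 4, 1.1-fold (0.03 log units) apart, within the scatter of two such steps. Within these four compounds, then, each change has about the same size on either core, but this rests on only two instances of each change and shows neither that the agreement extends to other groups or cores nor why the steps take these sizes.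

The compounds shown leave open whether a group such as nitrile or a carboxylic acid on that aromatic carbon would also leave the number within the scatter, given that chloro and methoxy are the only two groups compared there. They also leave open whether the step seen with (dimethylamino)methyl would carry over to a cyclic amine such as piperidine or to a longer chain between the ring carbon and the amine.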